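The compounds below may be only part of what the source reports. "The series", "measured", "known", "first", "only" and "open" are said of these compounds alone.

Measured so far:
compound 1 `O=C1Nc2ccc(Br)cc2/C1=N/NC(=S)N/N=C/c1c(F)cccc1Cl` — 2560 nM
compound 2 `COc1ccc(/C=N/NC(=S)N/N=C2\C(=O)Nc3ccc(C)cc32)cc1O` — 3190 nM
compound 3 `Cc1ccc(O)c(/C=N/NC(=S)N/N=C2\C(=O)Nc3ccc(C)cc32)c1` — limit, > 50000 nM

In a functional assay on COS-7 cells (Chlorocebus aethiops) for inhibition, read by MTT assay (on this read-out higher numbers stand for weaker inhibition and lower numbers for stronger inhibition), compound 1 gives 2560 nM, the lowest of the two numbers shown, and compound 2 gives 3190 nM, within the scatter of it. Compound 3 reaches only the assay limit of > 50000 nM. Within the data shown here, the one step that changes the aryl group on a carbon with a double bond to nitrogen, an at least 15-fold higher number from compound 2 to compound 3 (1.19 log units; beyond the scatter), shows that such a swap can matter a great deal, as seen in the limit of > 50000 nM in this assay, at which 1 of the 3 values shown sits.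

Compound 4 `O=C1Nc2ccc(Br)cc2/C1=N/NC(=S)N/N=C/c1ccc(Br)cc1` differs from compound 1 by 4-bromophenyl in place of 2-chloro-6-fluorophenyl on a carbon with a double bond to nitrogen. That is the same kind of change, so a step beyond the scatter is possible in either direction, and the expected step is a 1.6-fold higher number from compound 1 to compound 4 (0.19 log units; within the scatter). Compound 4 is therefore estimated at 4000 nM, between 1200 nM and 20000 nM.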

Compound 4, half-maximal inhibitory concentration: 5180 nM
Estimate against measurement, compound 4: 1.3-fold (0.11 log units) below; low and high end bracket the measured number.
By their numbers in this assay, from the lowest: compounds 1, 2 and 4 (each within the scatter of the next, the first and the last beyond it). At a limit, above all of these: compound 3.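

In this assay, a halogen-bearing phenyl on the core of compound 1 can be exchanged for another with only a modest cost: a 2.0-fold higher number from compound 1 to compound 4 (0.31 log units; beyond the scatter) is a small move, just beyond the scatter. So a change of aryl group at this place need not produce a large step, and compound 4 still gives a measured number. Nothing shown here gives a reason for this step.

From the compounds shown here alone, it remains open whether 4-bromophenyl owes its number to the bromine or to the loss of chlorine and fluorine. Going by these compounds, it also remains open how a phenyl carrying an amine or a carboxylic acid would fare at this place.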